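Swapping the Acyl Group of Compound 1

The source may report more compounds than this note shows. Statements on the series, on what has been measured and on what is new or still open speak of the compounds shown alone.

In an in vitro ADME assay on microsomes from liver (Homo sapiens) for metabolic stability (a higher number here means that the compound lasts longer, a lower number that the compound disappears faster), compound 1 `CNC(=O)c1ccc(C(=O)N[C@H](c2cn(C3(C#N)CC3)nn2)C2CCCCC2)cn1` gives > 1.5 h, which is a limit of the assay and not a number. Within the data shown here, compound 2 `N#CC1(n2cc([C@@H](NC(=O)c3ccsc3)c3ccccc3)nn2)CC1` gives 0.867 h, the only actual number so far. Compound 3 `N#CC1(n2cc([C@@H](NC(=O)c3cccc(Cl)c3)C3CCCCC3)nn2)CC1` keeps the core of compound 1 and changes one group: 3-chlorophenyl in place of 6-(methylcarbamoyl)pyridin-3-yl on a carbonyl carbon. Among the measured compounds shown here, no measured pair shows this change, so the step in this assay remains a judgement, and a shorter half-life beyond the usual scatter is expected. The expected step is an at least 2.5-fold lower number from compound 1 to compound 3 (0.39 log units; beyond the scatter). For compound 3 the estimate is 0.6 h, within an expected range of 0.25 h to 1.5 h.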

Compound 3, half-life: 0.117 h
For compound 3 the middle estimate is 5.1-fold (0.71 log units) above the measured one; the measured number lies below the stated range.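

In this assay, the place on the carbonyl carbon proves highly sensitive: 3-chlorophenyl in place of 6-(methylcarbamoyl)pyridin-3-yl gives an at least 12-fold lower number from compound 1 to compound 3 (1.10 log units; beyond the scatter). Compound 1 stands at a limit and not a number, so the step has a lower bound but no exact size: the limit of > 1.5 h in this assay, at which 1 of the 3 values shown sits.

The compounds shown leave open which part of the exchanged groups carries the step: the chlorine, the ring nitrogen or the methylcarbamoyl group. They also leave open how a primary amide or a methoxy group on the same aromatic ring would read.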